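This account rests on a few compounds, and the source may have more. Where it says the series, first, only, none or still open, it means among the compounds named here.

Going by the values given here, in a functional assay on HepG2 cells (Homo sapiens) for inhibition, read by MTT assay, with a stated time of 48 h (a lower number here means a stronger inhibitor, a higher number a weaker inhibitor), three compounds built on one shared core have numbers so far. Compound 1 `CCOC(=O)C1=C(N/C=N/c2nnc(S(N)(=O)=O)s2)Nc2[nH]nc(C)c2C1c1ccc(N(C)C)cc1` gives 38100 nM, compound 2 `CCOC(=O)C1=C(N/N=C(/C(=O)Br)c2ccc(Br)cc2)Nc2[nH]nc(C)c2C1c1ccc(N(C)C)cc1` gives 65000 nM, and compound 3 `CCOC(=O)C1=C(N/C=N/c2ncc(-c3ccccc3)s2)Nc2[nH]nc(C)c2C1c1ccc(N(C)C)cc1` gives 9790 nM. Two of these share the upper end of the range, the gap being a 1.7-fold higher number from compound 1 to compound 2 (0.23 log units; within the scatter). Only compound 3 lies clearly apart, its value well under that of compound 2.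

Compound 4 `CCOC(=O)C(=NNC1=C(C(=O)OCC)C(c2ccc(N(C)C)cc2)c2c(C)n[nH]c2N1)C(=O)OCC` keeps the shared core and differs from compound 2 at one place, on an amine nitrogen whose other neighbours are: double-bonded ring carbon. The change is a group of 12 heavy atoms (7 carbon, 1 nitrogen, 4 oxygen; no ring) in place of a group of 12 heavy atoms (8 carbon, 1 nitrogen, 1 oxygen, 2 bromine; one six-membered aromatic ring of carbon only), on an amine nitrogen. The aromatic ring and the bromine atoms leave, and the group that enters has no ring.

Among the compounds with values here, two measured steps bear on this. The one on an amine nitrogen, already cited above, stayed within the scatter although the groups exchanged there were very different. The other, a 3.9-fold lower number from compound 1 to compound 3 (0.59 log units; beyond the scatter), is modest and sits on a double-bonded nitrogen. Neither brings in a group without a ring, so the data give no firm direction. No step beyond the scatter is therefore expected in this assay, and the expected change is a 1.4-fold lower number from compound 2 to compound 4 (0.16 log units; within the scatter). Compound 4 is estimated at 45000 nM, with an expected range from 15000 nM to 110000 nM.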

Compound 4, half-maximal inhibitory concentration: 80800 nM
The estimate for compound 4 lay 1.8-fold (0.25 log units) below the measured number; the range from low to high includes it.
By their numbers in this assay, from the lowest: compound 3; then compounds 1, 2 and 4 (each within the scatter of the next, the first and the last beyond it).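

In this assay, the group with no ring replaces the group carrying the six-membered aromatic ring and the two bromine atoms with a 1.2-fold higher number from compound 2 to compound 4 (0.09 log units; within the scatter), so among these compounds, losing that ring and both bromine atoms on the amine nitrogen, while gaining hydrogen-bond acceptors, does not separate compound 4 from compound 2. Set against the group with the five-membered aromatic ring, the same group gives a 2.1-fold higher number from compound 1 to compound 4 (0.33 log units; beyond the scatter), a modest step and the first on this amine nitrogen to pass the scatter, since the step from compound 1 to compound 2 stayed within it. Nothing at hand gives a cause for either step.

What the compounds shown leave open is how a far smaller group on this amine nitrogen, such as a methyl or an acetyl, or a group bearing a carboxylic acid or an amine, would read in this assay. Going by these compounds, it also remains open whether a group with no ring can come near compound 3, which gives 9790 nM with its 5-phenyl-1,3-thiazol-2-yl on a double-bonded nitrogen.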